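Chain-length extension and half-life in a carbamate series

The source may report more compounds than this note shows. Statements on the series, on what has been measured and on what is new or still open speak of the compounds shown alone.

Compound 1, `CCCCCCCCCNC(=O)Oc1ccc(Cl)cc1C(=O)Nc1cccc(Cl)c1`, compound 2, `CCCCCCCCCCNC(=O)Oc1ccc(Cl)cc1C(=O)Nc1cccc(Cl)c1`, and compound 3, `CCCCCNC(=O)Oc1ccc(Cl)cc1C(=O)Nc1ccc(Cl)cc1`, have been measured in an ADME assay for metabolic stability, read by HPLC, at pH 7; a higher number here means that the compound lasts longer, a lower number that the compound disappears faster. In this assay compound 1 gives 64 h, compound 2 gives 64 h, and compound 3 gives 64 h. Within the data shown here, the one change from compound 1 to compound 2 is methyl in place of hydrogen on a saturated chain carbon, nine bonds along the chain from an amide-type nitrogen, and the step it made, no change at the digits printed from compound 1 to compound 2 (within the scatter), lies within the scatter. Compound 3 stands level with both of them; the difference between the core of compound 1 and the core of compound 3 is not broken down here.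

Compound 4, `CCCCCCNC(=O)Oc1ccc(Cl)cc1C(=O)Nc1ccc(Cl)cc1`, has not yet been measured. It differs from compound 3 by methyl in place of hydrogen on a saturated chain carbon, five bonds along the chain from an amide-type nitrogen. Among the measured compounds shown here, this is the same kind of change as the one from compound 1 to compound 2, but not the same: there the methyl enters nine bonds along the chain from an amide-type nitrogen, here it enters five bonds along the chain from an amide-type nitrogen. Because the earlier step, no change at the digits printed from compound 1 to compound 2 (within the scatter), made no change at the digits printed, and because compound 3 at 64 h sits where compounds 1 and 2 sit, a step from compound 3 to compound 4 of no change at the digits printed from compound 3 to compound 4 (within the scatter) is expected in this assay. Compound 4 is therefore estimated at 64 h, with a range from 32 h to 128 h allowing for the usual scatter.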

Compound 4, half-life: 64 h
For compound 4 middle estimate and measured number coincide at the digits printed; low and high end bracket the measured number.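

Methyl in place of hydrogen on a saturated chain carbon, five bonds along the chain from an amide-type nitrogen, gave in this assay a result of no change at the digits printed from compound 3 to compound 4 (within the scatter), while the same kind of change on the core of compound 1, nine bonds along the chain, gave no change at the digits printed from compound 1 to compound 2 (within the scatter). Set side by side, the two steps do not differ, so within these four compounds the change carries from one core to the other without a visible difference: the same change on two cores in this assay, no change at the digits printed (within the scatter) from compound 1 to compound 2 and no change at the digits printed (within the scatter) from compound 3 to compound 4, 1.0-fold (0.00 log units) apart, within the scatter of two such steps

This agreement rests on two cores only, and the methyl enters at a different place on each, so it does not separate the effect of the core from that of the place, and it does not show that the change would leave the half-life untouched on any other core or at any other chain length.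

What the compounds shown leave open is whether the result holds for a chain shorter than that of compound 3, such as propyl, for a branched chain, or for a chain ending in an amine or a carboxylic acid. On these data alone, it is also open whether a urea or an amide in place of the carbamate would stand level with compounds 1 to 4 in this assay.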